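Bromo on Compound 3: A Small Expected Step

The compounds below may be only part of what the source reports. "The series", "measured", "known", "first", "only" and "open" are said of these compounds alone.

In a functional assay on LoVo cells (Homo sapiens) for antiproliferative activity, read by MTT assay, with a stated time of 72 h (a higher number here means a weaker inhibitor, a lower number a stronger inhibitor), compound 1 `O=C1Nc2c(F)cccc2/C1=C1/Nc2ccccc2C1=O` gives 42000 nM and compound 3 `O=C1Nc2ccccc2/C1=C1/Cc2ccccc2C1=O` gives 52600 nM, two values within the scatter of each other. Compound 2 `O=C1Nc2c(Cl)cccc2/C1=C1/Nc2ccccc2C1=O` is reported only as a limit, > 100000 nM. Compound 4 `O=C1Nc2ccc(Br)cc2/C1=C1/Cc2ccccc2C1=O` differs from compound 3 by bromo in place of hydrogen on an aromatic carbon. For the measured compounds named here, no measured step adds a halogen in place of hydrogen. The closest evidence, on the core of compound 1, is chloro in place of fluoro on an aromatic carbon: an at least 2.3-fold higher number from compound 1 to compound 2 (0.37 log units; beyond the scatter). That indirect step suggests, weakly, a higher number in this assay, so little change beyond the scatter is expected. The expected step is a 1.1-fold higher number from compound 3 to compound 4 (0.06 log units; within the scatter). For compound 4 the estimated value is 60000 nM, within an expected range of 20000 nM to 150000 nM.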

Compound 4, half-maximal inhibitory concentration: 52800 nM
Beside the measured number, compound 4's estimate is 1.1-fold (0.06 log units) above it; low and high end bracket the measured number.
By their numbers in this assay, from the lowest: compounds 1, 3 and 4 (each within the scatter of the next). At a limit, above all of these: compound 2.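

In this assay, bromo in place of hydrogen on an aromatic carbon gives a 1.0-fold higher number from compound 3 to compound 4 (0.00 log units; within the scatter), the only direct reading among these compounds of a halogen entering in place of hydrogen. At this place, meta to a fused ring and para to a fused ring, the change stays within the scatter, and compound 4 keeps a measured number. Compound 2 alone stands at a limit: the limit of > 100000 nM in this assay, at which 1 of the 4 values shown sits.

From the compounds shown here alone, whether an amine, a carboxylic acid or a longer chain at this place would shift the number stays open. So does whether bromo would behave alike on the core of compound 1.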